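The compounds below may be only part of what the source reports. "The series", "measured", "known", "first", "only" and "open" are said of these compounds alone.

All three measured compounds were tested in a functional assay on HepG2 cells (Homo sapiens) for cytotoxicity, read by MTT assay, with a stated time of 72 h; on this read-out lower numbers stand for stronger inhibition and higher numbers for weaker inhibition.

Compound 1 `Cc1cc(=O)n(-c2cccc(F)c2)nc1C(=O)Nc1ccc(Oc2ncnc3[nH]ccc23)cc1`: 3180 nM
Compound 2 `Cc1ccc(-n2nc(C(=O)Nc3ccc(Oc4ncnc5[nH]ccc45)cc3)c(C)cc2=O)cc1`: 7460 nM
Compound 3 `Cc1cc(=O)n(-c2cccc(F)c2)nc1C(=O)Nc1ccc(Oc2ncnc3c2ccn3C)cc1`: > 60000 nM

Compound 1 and compound 2 share one core and differ in a single place, (4-methylphenyl in place of 3-fluorophenyl on an aromatic nitrogen). In this assay that change produced a 2.3-fold higher number from compound 1 to compound 2 (0.37 log units; beyond the scatter). Compound 3 has a different core: its difference from compound 1 is methyl in place of hydrogen on an aromatic nitrogen. The value of compound 3 is a limit of this assay and not a number. The step is an at least 18-fold higher number from compound 1 to compound 3 (1.27 log units; beyond the scatter).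

Compound 4 `Cc1ccc(-n2nc(C(=O)Nc3ccc(Oc4ncnc5c4ccn5C)cc3)c(C)cc2=O)cc1` has not yet been measured in this assay. It differs from compound 3 by 4-methylphenyl in place of 3-fluorophenyl on an aromatic nitrogen, the same change that separates compound 1 and compound 2, made on the core of compound 3. Because that earlier step was a 2.3-fold higher number from compound 1 to compound 2 (0.37 log units; beyond the scatter), a step toward a higher number is expected here as well, and because compound 3 already sits at the limit of > 60000 nM in this assay, at which 1 of the 3 values shown sits, the result for compound 4 is expected to be a limit again. The estimated step is a step that the limit leaves unreadable from compound 3 to compound 4. The estimated value of compound 4 is 120000 nM.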

Compound 4, half-maximal inhibitory concentration: 33800 nM
For compound 4 the middle estimate is 3.6-fold (0.55 log units) above the measured one; the whole stated range lies above it.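

Swapping 3-fluorophenyl for 4-methylphenyl did not behave the same way on the two cores. On the core carrying the added methyl it gave an at least 1.7-fold lower number from compound 3 to compound 4 (0.24 log units; that floor lies within the scatter), and set beside the step on the other core, the two results differ: the same change on two cores in this assay, a 2.3-fold higher number (0.37 log units; beyond the scatter) from compound 1 to compound 2 and an at least 1.7-fold lower number (0.24 log units; that floor lies within the scatter) from compound 3 to compound 4, at least 4.1-fold (0.61 log units) apart, beyond the scatter of two such steps
Adding methyl on the aromatic nitrogen raised the number on both phenyl variants, including a 4.5-fold higher number from compound 2 to compound 4 (0.66 log units; beyond the scatter), yet the size of that step did not carry over unchanged: the same change on two cores in this assay, an at least 18-fold higher number (1.27 log units; beyond the scatter) from compound 1 to compound 3 and a 4.5-fold higher number (0.66 log units; beyond the scatter) from compound 2 to compound 4, at least 4.1-fold (0.61 log units) apart, beyond the scatter of two such steps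
Compound 3 stands at > 60000 nM in this assay, which is a limit of the assay and not a number, so every step involving it is only a bound, and these compounds do not show why the phenyl swap depends on the core.

Going by these compounds, with two phenyl groups and two cores, this comparison rests on a single set of four compounds, and it remains open whether the core dependence would hold for another group, such as methoxy or chlorine on the phenyl ring. On these data alone, it is also open how a longer chain, such as ethyl, or a chain ending in an amine would compare with methyl on the aromatic nitrogen.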